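Swapping cyclopropyl for allyl on a nitrogen

A few compounds are considered here, and "the series" means these few. Any claim that something is new, unique, unknown or untested is made for them only; others in the source may bear on it.

compound 1 `Nc1ccccc1Nc1n[n+]([O-])c2ccccc2[n+]1[O-]` gives 17400 nM
compound 2 `[O-][n+]1nc(NC2CC2)[n+]([O-])c2ccccc21` gives 13300 nM
compound 3 `Cc1ccc(Nc2n[n+]([O-])c3ccccc3[n+]2[O-])cc1` gives 10600 nM

In a functional assay on HepG2 cells (Homo sapiens) for cytotoxicity, read by MTT assay, with a stated time of 48 h (a lower number here means a stronger inhibitor, a higher number a weaker inhibitor), compound 2 at 13300 nM lies within the usual scatter of both compound 1 and compound 3, so these three cannot be ranked. The unmeasured compound 4 `C=CCNc1n[n+]([O-])c2ccccc2[n+]1[O-]` differs from compound 2 by one swap, allyl in place of cyclopropyl on a nitrogen on an aromatic ring in full, with allyl in place of cyclopropyl on a nitrogen on an aromatic ring. For the measured compounds named here, no measured pair shows this swap. Still, compound 3 at 10600 nM carries a different group on that nitrogen and stays within the scatter of compound 2, so no step beyond the scatter is expected in this assay for this change. The estimated 1.1-fold higher number from compound 2 to compound 4 (0.02 log units; within the scatter) stays inside the scatter. Compound 4 is expected at about 14000 nM with an estimated range from 7500 nM to 26000 nM in all.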

Compound 4, half-maximal inhibitory concentration: > 56000 nM
Compound 4: a limit, no number; the forecaster's own chance of this, stated with the estimate: 6%; middle value at least 4.0-fold (0.60 log units) away from the limit.
By their numbers in this assay, from the lowest: compounds 3, 2 and 1 (each within the scatter of the next). At a limit, above all of these: compound 4.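

In this assay, the group on this nitrogen matters more than compounds 1, 2 and 3 suggested, as those three could not be ranked. Allyl in place of cyclopropyl, with the same count of heavy atoms, gives an at least 4.2-fold higher number from compound 2 to compound 4 (0.62 log units; beyond the scatter) and so moves beyond the scatter. Compound 4 has a limit, not a number: the limit of > 56000 nM in this assay, at which 1 of the 4 values shown sits.

From the compounds shown here alone, it remains open whether losing the ring or gaining the double bond matters here. A propyl chain on this nitrogen, which has neither, could help separate the two.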